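This account rests on a few compounds, and the source may have more. Where it says the series, first, only, none or still open, it means among the compounds named here.

Compound 1 `COc1ccc(-c2c(S(=O)(=O)c3ccc(C)c(C)c3)cnc3cc(F)ccc23)cc1`: 4.13 mL/min
Compound 2 `Cc1ccc(S(=O)(=O)c2cnc3cc(F)ccc3c2-c2cccc(Cl)c2)cc1C`: 4.01 mL/min
Compound 3 `Cc1ccc(S(=O)(=O)c2cnc3cc(F)ccc3c2-c2ccc(Cl)cc2)cc1C`: 7.88 mL/min

These three compounds share a core and have been measured in an ADME assay on microsomes from liver (Homo sapiens) for metabolic stability, tested at 2.5 uM; on this read-out higher numbers stand for fast clearance and lower numbers for slow clearance. Compound 2 sits at the low end of the three numbers, yet a 1.0-fold lower number from compound 1 to compound 2 (0.01 log units; within the scatter) and a 2.0-fold higher number from compound 2 to compound 3 (0.29 log units; within the scatter) both fall within the scatter, as does a 1.9-fold higher number from compound 1 to compound 3 (0.28 log units; within the scatter). Compound 4 `Cc1ccc(S(=O)(=O)c2cnc3cc(F)ccc3c2-c2cccc(Cl)c2)cc1F` differs from compound 2 by fluoro in place of methyl on an aromatic carbon. Going by the values given here, every measured step concerns the 4-methoxyphenyl, 3-chlorophenyl or 4-chlorophenyl group; none alters the 3,4-dimethylphenyl, so no measured step bears directly on this change. Since all three measured steps lie within the scatter, no step beyond the scatter is expected in this assay. Compound 4 is therefore expected to give 4 mL/min, with a range from 2 mL/min to 8 mL/min. The expected step is a 1.0-fold lower number from compound 2 to compound 4 (0.00 log units; within the scatter).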

Compound 4, intrinsic clearance in a liver preparation (reported as CLH), per the amount of preparation that the assay uses: 2.13 mL/min
Beside the measured number, compound 4's estimate is 1.9-fold (0.27 log units) above it; low and high end bracket the measured number.
By their numbers in this assay, from the lowest: compounds 4, 2, 1 and 3 (each within the scatter of the next, the first and the last beyond it).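

In this assay, the change from 3,4-dimethylphenyl to 3-fluoro-4-methylphenyl, the only step shown on this ring, gives a 1.9-fold lower number from compound 2 to compound 4 (0.27 log units; within the scatter). With fluoro in place of methyl at this position, ortho to a methyl group, the read-out therefore stays within the scatter for this one pair. Nothing shown explains the size of this step.

From the compounds shown here alone, it remains open whether the same change would behave alike with the 4-methoxyphenyl of compound 1 or the 4-chlorophenyl of compound 3. Going by these compounds, it is also open how a nitrile or an amine would read at this position.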